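Naphthoquinone amides: chain lengthening and cytotoxicity on KB cells

A few compounds are considered here, and "the series" means these few. Any claim that something is new, unique, unknown or untested is made for them only; others in the source may bear on it.

Measured so far:
compound 1, `CCCC(C)C(=O)NCC(C)(C)CC1=C(O)C(=O)c2ccccc2C1=O`, 47100 nM;
compound 2, `CCCCCCCC(=O)NCC(C)(C)CC1=C(O)C(=O)c2ccccc2C1=O`, 24600 nM;
compound 3, `CCCCCCC(C)C(=O)NCC(C)(C)CC1=C(O)C(=O)c2ccccc2C1=O`, 23700 nM.

All three numbers come from a functional assay on KB cells (Homo sapiens) for cytotoxicity, read by resazurin assay, with a stated time of 3 days; a higher number here means a weaker inhibitor, a lower number a stronger inhibitor. Compound 2 stands second highest of the three; its nearest neighbour is compound 3 at a 1.0-fold lower number from compound 2 to compound 3 (0.02 log units; within the scatter), its furthest compound 1, from which it is separated by a 1.9-fold lower number from compound 1 to compound 2 (0.28 log units; within the scatter). None of the three pairs is separated by more than the scatter.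

Compound 4, `CCCCCCCCCCCC(=O)NCC(C)(C)CC1=C(O)C(=O)c2ccccc2C1=O`, is not yet measured. It differs from compound 2 by butyl in place of hydrogen on a saturated chain carbon, seven bonds along the chain from a carbonyl carbon. Going by the values given here, the steps that bear on this are the two chain-growing steps: a 1.9-fold lower number from compound 1 to compound 2 (0.28 log units; within the scatter) and a 2.0-fold lower number from compound 1 to compound 3 (0.30 log units; within the scatter), both within the scatter, and both pointing, if anywhere, toward a lower number. Extending the chain further is therefore expected to leave the number in this assay close to that of compound 2, with at most a small downward drift.

The estimate for compound 4 is 18000 nM, range 8000 nM to 40000 nM, which means an expected step of a 1.4-fold lower number from compound 2 to compound 4 (0.14 log units; within the scatter) from compound 2.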

Compound 4, half-maximal inhibitory concentration: 12800 nM
Compound 4: middle estimate off by 1.4-fold (0.15 log units), on the high side; measured number inside the range.
By their numbers in this assay, from the lowest: compounds 4, 3, 2 and 1 (each within the scatter of the next, the first and the last beyond it).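

At the saturated chain carbon seven bonds along the chain from a carbonyl carbon, butyl in place of hydrogen gives a 1.9-fold lower number from compound 2 to compound 4 (0.28 log units; within the scatter) in this assay. The earlier compounds shown here did not carry the straight chain this far out, and this step shows that a further 4 carbon atoms at this position, with no ring and no hydrogen-bond donor or acceptor, leave compound 4 within the scatter of compound 2. No measurement shown here accounts for this result.

On these data alone, whether a longer chain would stay within the scatter of compound 4 remains open. So does the effect of an amine or a carboxylic acid at this position, and whether methyl branching on this longer chain would change the number.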